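Methyl on the saturated ring and tolerated concentration

This account rests on a few compounds, and the source may have more. Where it says the series, first, only, none or still open, it means among the compounds named here.

Measured compounds:
compound 1, `O=c1cc(Cc2c(F)cccc2F)nc(N2CCCCC2)[nH]1`, > 82000 nM
compound 2, `CC1CCN(c2nc(Cc3c(F)cccc3F)cc(=O)[nH]2)CC1`, > 78000 nM
compound 3, `Cc1c(C(C)c2c(F)cccc2F)nc(N2CCCCC2)[nH]c1=O`, > 75000 nM

Three compounds have been run through an ADME assay on MT4 cells (Homo sapiens) for cytotoxicity, read by MTT assay, with a stated time of 4 days; a lower number here means that less compound is tolerated, a higher number that more compound is tolerated. For compound 1 the result is a limit of the assay, > 82000 nM. For compound 2 the result is likewise a limit, > 78000 nM. For compound 3 the result is again a limit, > 75000 nM. Each of the three values is thus a limit: the limit of > 82000 nM in this assay, at which 1 of the 3 values shown sits, the limit of > 78000 nM in this assay, at which 1 of the 3 values shown sits, and (the limit of > 75000 nM in this assay, at which 1 of the 3 values shown sits). The change methyl in place of hydrogen on a saturated ring carbon gives a step that the two limits leave unreadable from compound 1 to compound 2. The difference between the cores of compound 1 and compound 3 is not broken down here.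

Compound 4 `Cc1c(C(C)c2c(F)cccc2F)nc(N2CCCC(C)C2)[nH]c1=O` has not yet been measured. It differs from compound 3 by methyl in place of hydrogen on a saturated ring carbon. This is the same kind of change as that from compound 1 to compound 2, but the place differs: in compound 2 the methyl sits three ring bonds from the ring nitrogen and three ring bonds from the ring atom that bears a large group, whereas in compound 4 it sits two ring bonds from each. The measured step from compound 1 to compound 2 is left unreadable by the two limits. The expectation for compound 4 therefore rests only on the three measured compounds all sitting at a limit in this assay. The step expected from compound 3 to compound 4 is a step that the limit leaves unreadable from compound 3 to compound 4. Compound 4 is expected to give 80000 nM in this assay, estimated to lie between 40000 nM and 200000 nM, and most probably to be reported again only as a limit.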

Compound 4, half-maximal cytotoxic concentration: > 72000 nM
Compound 4 ended at the assay's limit; the forecaster's own chance of this, stated with the estimate: 85%; the middle value is on the limit's open side.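

In this assay compound 4 gives > 72000 nM, which is a limit of the assay. The result for compound 3 is also a limit, so no step can be read from compound 3 to compound 4. The compounds shown leave open what concentration any of compounds 1 to 4 actually tolerates, and whether methyl in place of hydrogen on the saturated ring changes it at either place.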